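Methylpyrrole in Place of Furan on the Fused Core

This account rests on a few compounds, and the source may have more. Where it says the series, first, only, none or still open, it means among the compounds named here.

Measured compounds:
compound 1 `Cc1occc1-c1nnc2sc(-c3cc(O)nc(O)c3)nn12` — 11.4%
compound 2 `COc1ccc(Cl)c(-c2nnc3n2NC(c2ccco2)S3)c1` — 18.7%

Of the compounds shown here, two have been tested in a functional assay on the whole organism (strain Wistar Albino) for inhibition, with Rattus norvegicus as the target, read by paw edema, with a stated time of 2 h, at a dose of 20 mg/kg; a lower number here means less inhibition, a higher number more inhibition at the dose given (going by the name of the read-out). Compound 1 gives 11.4% in this assay, and compound 2 gives 18.7%. Among the compounds with values here, of the two numbers, the one for compound 2 is the upper, yet its gap to compound 1 lies within the usual scatter of repeated measurements, so the two compounds cannot be told apart on these data alone. Within the data shown here, the two structures differ in several places at once, and no single-change step between measured compounds is available, so nothing can yet be said about how any one change moves the read-out.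

Compound 3 `COc1ccc(Cl)c(-c2nnc3n2NC(c2cccn2C)S3)c1` has not been measured. It differs from compound 2 in one place: 1-methyl-1H-pyrrol-2-yl in place of furan-2-yl on a saturated ring carbon. Among the measured compounds shown here, with no measured step to lean on, the change is expected to move the read-out by at most a small amount, in no preferred direction, and not beyond the scatter, which is what a number 0.7 percentage points lower from compound 2 to compound 3 (within the scatter) means. Compound 3 is therefore estimated at 18%, within a range from 7% to 30%.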

Compound 3, a percentage reported as inhibition, in the whole organism at one dose (the size of the read-out at that dose, not a potency): 16.8%
The estimate for compound 3 lay 1.2 percentage points above the measured number, within the range that was stated.
By their numbers in this assay, from the lowest: compounds 1, 3 and 2 (each within the scatter of the next).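

In this assay, within the data shown here, the exchange of furan-2-yl for 1-methyl-1H-pyrrol-2-yl on a saturated ring carbon provides the only single-place step available so far: a number 1.9 percentage points lower from compound 2 to compound 3 (within the scatter). At this position, therefore, these two five-membered aromatic rings, each with 1 hetero atom, cannot be told apart by this read-out, even though the entering group has 6 heavy atoms and the leaving group 5. No other measurement bears on this result, so it rests on the paw edema numbers alone.

The compounds shown leave open whether the read-out responds at all to a different kind of group on this saturated ring carbon, such as an amine, a carboxylic acid or a longer chain in place of the five-membered aromatic ring. They also leave open whether the same exchange would read alike on the core of compound 1, or at a dose or time other than those of this assay.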